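Taking the methoxy group off compound 1

A few compounds are considered here, and "the series" means these few. Any claim that something is new, unique, unknown or untested is made for them only; others in the source may bear on it.

Going by the values given here, in a functional assay on THP-1 cells (Homo sapiens) for inhibition, read by sulforhodamine B assay, with a stated time of 48 h, tested at 50 uM (on this read-out lower numbers stand for less inhibition of growth and higher numbers for more inhibition of growth at the one concentration tested), compound 1 (`COc1cccc(/C=C/C(=O)/C=C/c2ccc(OCc3cn(CCCOc4cc(=O)oc5ccccc45)nn3)c(OC)c2)c1`) gives 58% and stands highest of the two numbers so far. Compound 2 (`COc1ccccc1/C=C/C(=O)/C=C/c1ccc(OCc2cn(CCCCCOc3cc(=O)oc4ccccc34)nn2)c(OC)c1`) reaches 37% there, lower by a gap beyond the usual scatter. These two compounds differ in more than one place, so no single structural change can be read from their gap.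

Compound 3 (`COc1cc(/C=C/C(=O)/C=C/c2ccccc2)ccc1OCc1cn(CCCOc2cc(=O)oc3ccccc23)nn1`) departs from compound 1 in one place (hydrogen in place of methoxy on an aromatic carbon): hydrogen in place of methoxy on an aromatic carbon, so that 3-methoxyphenyl becomes phenyl. Among the compounds with values here, no measured pair shows this change, so the expectation in this assay is only a small drop in growth inhibition, perhaps none beyond the scatter. Within the data shown here, the one anchor is compound 1 at 58% and the estimate stays near that number. The expected change is a number 6 percentage points lower from compound 1 to compound 3 (within the scatter) as an estimate, and it carries wide uncertainty. For compound 3 the estimated value is 52% with an expected range from 35% to 70% in this measurement.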

Compound 3, percent growth inhibition at one concentration: 48%
The estimate for compound 3 lay 4 percentage points above the measured number, and the stated range covers the measured number.
By their numbers in this assay, from the lowest: compound 2; then compounds 3 and 1 (each within the scatter of the next).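

Going by these compounds alone, the first single-place step in this assay reads a number 10 percentage points lower from compound 1 to compound 3 (within the scatter), so the change from 3-methoxyphenyl to phenyl is not resolved from the usual scatter of this read-out. Within the data shown here, until now, the only comparison was a gap between two compounds that differ in more than one place, and it could not be assigned to any one structural change. This pair shows that, at this one concentration, the methoxy group on this aromatic carbon, meta to a large group, is not required for compound 3 to keep a number within the scatter of compound 1, although a small real loss cannot be excluded from a single step of this size. Nothing in the data offers an explanation for the step or ties any property to the methoxy group.

What the compounds shown leave open is whether another group at this place, such as an amine, a carboxylic acid or a hydroxyl, would move the number beyond the scatter. They also leave open whether hydrogen in place of methoxy would give a similar step on a compound with a different chain or at other concentrations.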